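The compounds below may be only part of what the source reports. "The series", "measured", "known", "first", "only" and "open" are said of these compounds alone.

Notes on the series. In an assay on HeLa cells for displacement of a labelled ligand from 5-hydroxytryptamine receptor 6 (Homo sapiens) (a higher number here means a weaker inhibitor, a lower number a stronger inhibitor), compound 1 `Cc1ccc(S(=O)(=O)c2n[nH]c3ccc(N4CCN(C)CC4)cc23)cc1` gives 4.9 nM. Among the three numbers recorded this is the second highest: compound 3 `CC(C)Cn1nc(S(=O)(=O)c2cccc3ccccc23)c2cc(N3CCN(C)CC3)ccc21`, the nearest, gives 1.4 nM in this assay, a lower number beyond the scatter, while compound 2 `O=S(=O)(c1cccc(F)c1)c1n[nH]c2cccc(N3CCNCC3)c12`, the furthest, gives 134 nM, a higher number well beyond the scatter. Within the data shown here, no single-point step between measured compounds is available, so the step to compound 4 `COc1cccc(S(=O)(=O)c2n[nH]c3ccc(N4CCN(C)CC4)cc23)c1` rests on the change alone: 3-methoxyphenyl in place of 4-methylphenyl on a sulfonyl sulfur. For compound 4 a small step is expected, in the direction of a somewhat higher number, and it may well fall within the scatter, so compound 4 is estimated at 7 nM (range 2 nM to 25 nM), a step of a 1.4-fold higher number from compound 1 to compound 4 (0.15 log units; within the scatter).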

Compound 4, inhibition constant: 1.1 nM
Beside the measured number, compound 4's estimate is 6.4-fold (0.80 log units) above it; the whole stated range lies above it.
By their numbers in this assay, from the lowest: compounds 4 and 3 (each within the scatter of the next); then compound 1; then compound 2.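

Compound 4 gives the series its first comparison at a single place: 3-methoxyphenyl in place of 4-methylphenyl on a sulfonyl sulfur brings a 4.5-fold lower number from compound 1 to compound 4 (0.65 log units; beyond the scatter). The aryl group on this sulfur therefore moves the number, and the larger group, which adds one hydrogen-bond acceptor, is accepted here. Nothing available accounts for the lower number.

Still open, as far as these compounds go, is whether the step follows the methoxy group itself or its place on the phenyl ring. From the compounds shown here alone, how a 3-methylphenyl or 3-hydroxyphenyl group would read on the same sulfur also remains open.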